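The compounds below may be only part of what the source reports. "The series", "measured", "known", "first", "only" and "open" are said of these compounds alone.

Compound 2 `CCCS(=O)(=O)Nc1ccc(F)c(C(=O)c2n[nH]c3ncc(-c4ccc(C(C)C)cc4)cc23)c1F` gives 17% in an assay for binding affinity to dual specificity mitogen-activated protein kinase kinase 4 (Homo sapiens), read by KINOMEscan, tested at 100 nM (on this read-out lower numbers stand for a stronger effect and higher numbers for a weaker effect at the one concentration tested), and stands lowest of the two numbers; compound 1 `CCCS(=O)(=O)Nc1ccc(F)c(C(=O)c2n[nH]c3ncc(-c4cccc(Cl)c4)cc23)c1F` gives 40%. Among the measured compounds shown here, the one recorded step, a number 23 percentage points lower from compound 1 to compound 2 (beyond the scatter), swaps one aryl group for another and so bears only indirectly on compound 3 `CCCS(=O)(=O)Nc1ccc(F)c(C(=O)c2n[nH]c3ncc(-c4ccc(C(C)(C)C)cc4)cc23)c1F`, which differs from compound 2 by methyl in place of hydrogen on a saturated chain carbon bound to an aromatic carbon and two saturated chain carbons. That change is smaller than the measured one, so the expected step of a number 2 percentage points lower from compound 2 to compound 3 (within the scatter) is taken to lie within the scatter, in no settled direction. Compound 3 is accordingly estimated at 15%, with a range from 4% to 35%.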

Compound 3, a percentage reported as activity, at one concentration (the size of the read-out at that concentration, not a potency): 46%
Compound 3: middle estimate off by 31 percentage points, on the low side; measured number above the stated range.
By their numbers in this assay, from the lowest: compound 2; then compounds 1 and 3 (each within the scatter of the next).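

In this assay, the one methyl that turns isopropyl into tert-butyl gives a number 29 percentage points higher from compound 2 to compound 3 (beyond the scatter), so a single added carbon on this saturated chain carbon is enough to move the read-out beyond the scatter. With a number 6 percentage points higher from compound 1 to compound 3 (within the scatter), the 4-(tert-butyl)phenyl and 3-chlorophenyl groups cannot be told apart here. No available evidence accounts for the effect of the added methyl. Open, as far as these compounds go, is where a cyclopropyl or ethyl group in the same place would fall relative to isopropyl and tert-butyl. Also open, from the compounds shown here alone, is how a 4-aminophenyl or 4-carboxyphenyl group would read in this assay.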